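The compounds below may be only part of what the source reports. "The series", "measured", "known", "first", "only" and "open" are said of these compounds alone.

Of the compounds shown here, two sharing one core have been measured in a functional assay on SK-OV-3 cells (Homo sapiens) for cytotoxicity, read by MTT assay, with a stated time of 48 h; a lower number here means a stronger inhibitor, a higher number a weaker inhibitor. Compound 1 `O=c1[nH]c2ccccc2cc1-c1nc2cc(F)ccc2[nH]1` carries a fluoro group on an aromatic carbon of its core and gives 18300 nM. Compound 2 `O=c1[nH]c2ccccc2cc1-c1nc2cc(Br)ccc2[nH]1` carries a bromo group in the same place, and in this assay compound 2 gives 11400 nM. Among the measured compounds shown here, the step of a 1.6-fold lower number from compound 1 to compound 2 (0.21 log units; within the scatter) is the only comparison available, and it lies within the scatter, so the two compounds cannot be ranked against each other. Compound 3 `O=c1[nH]c2ccccc2cc1-c1nc2cc([N+](=O)[O-])ccc2[nH]1` is the next structure: nitro in place of bromo on an aromatic carbon. For the measured compounds named here, no measured step involves a nitro group, so the halogen swap is the only guide, and it showed nothing beyond the scatter. Compound 3 is therefore expected to stay close, with a step of about a 1.1-fold higher number from compound 2 to compound 3 (0.02 log units; within the scatter). Compound 3 is estimated at 12000 nM in this assay, with a likely range from 4000 nM to 40000 nM, the breadth reflecting that nothing measured here speaks to a nitro group.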

Compound 3, half-maximal inhibitory concentration: > 100000 nM
Compound 3 ended at the assay's limit; the forecaster's own chance of this, stated with the estimate: 10%; middle value at least 8.3-fold (0.92 log units) from the limit.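

Swapping one halogen for another at this aromatic carbon changed nothing that could be read, but the position is not indifferent to every group. In this assay, nitro in place of bromo gives an at least 8.7-fold higher number from compound 2 to compound 3 (0.94 log units; beyond the scatter), and nitro in place of fluoro gives an at least 5.4-fold higher number from compound 1 to compound 3 (0.73 log units; beyond the scatter), which makes compound 3 the weakest of the three compounds. The value of compound 3 is a limit of the assay and not a number, and the full size of both steps remains unknown: the limit of > 100000 nM in this assay, at which 1 of the 3 values shown sits.

The compounds shown leave open whether this loss is particular to nitro or extends to other non-halogen groups, such as an amine, a methoxy group or a carboxylic acid on the same aromatic carbon. They also leave open how the core with only hydrogen at this carbon would compare.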